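The compounds below may be only part of what the source reports. "The series", "measured", "known", "first", "only" and "open" are said of these compounds alone.

Compound 1, `Nc1scc(CN2CCN(c3cccc(C(F)(F)F)c3)CC2)c1C(=O)c1ccc(Cl)cc1`, gives -8.2% in a functional assay on CHO cells with adenosine receptor A1 (Homo sapiens) as the target, read by cAMP accumulation and immunoassay, with a stated time of 6 min, tested at 0.01 uM; on this read-out lower numbers stand for a stronger effect and higher numbers for a weaker effect at the one concentration tested.
Compound 2, `Nc1scc(CN2CCN(c3ccncc3)CC2)c1C(=O)c1ccc(Cl)cc1`, gives -4%.
Compound 3, `Nc1scc(CN2CCN(c3cccc4ccccc34)CC2)c1C(=O)c1ccc(Cl)cc1`, gives 8.7%.

All three share one core and differ only in the aromatic group attached to the amine nitrogen of the six-membered ring with two nitrogens. Compound 3, which carries naphthalen-1-yl there, has the highest number of the three: the step of a number 16.9 percentage points higher from compound 1 to compound 3 (beyond the scatter) and the step of a number 12.7 percentage points higher from compound 2 to compound 3 (beyond the scatter) both lie beyond the scatter, while the step of a number 4.2 percentage points higher from compound 1 to compound 2 (within the scatter) lies within it.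

Compound 4, `Nc1scc(CN2CCN(c3cccc(Cl)c3)CC2)c1C(=O)c1ccc(Cl)cc1`, differs from compound 3 by 3-chlorophenyl in place of naphthalen-1-yl on an amine nitrogen in a ring. The two steps that bear on this change are the ones in which a single six-membered aromatic ring was replaced by naphthalen-1-yl, and both raised the number by a modest amount. Here the change runs the other way, back to a single ring bearing one group, much like 3-(trifluoromethyl)phenyl in compound 1. A modest drop beyond the scatter is therefore expected. For compound 4 the estimate is -5%, with a likely range from -20% to 10%. This corresponds to an expected step of a number 13.7 percentage points lower from compound 3 to compound 4 (beyond the scatter).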

Compound 4, a percentage reported as activity, at one concentration (the size of the read-out at that concentration, not a potency): -3.1%
For compound 4 the middle estimate is 1.9 percentage points below the measured one, and the stated range covers the measured number.
By their numbers in this assay, from the lowest: compounds 1, 2 and 4 (each within the scatter of the next); then compound 3.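

The step of a number 11.8 percentage points lower from compound 3 to compound 4 (beyond the scatter) shows the pattern in reverse: replacing naphthalen-1-yl, with its two aromatic rings, by 3-chlorophenyl, with one, lowers the number in this assay, so compound 3 now stands apart from three compounds with a single aromatic ring on this nitrogen. Among those three, neither a number 5.1 percentage points higher from compound 1 to compound 4 (within the scatter), where chloro replaces trifluoromethyl, nor a number 0.9 percentage points higher from compound 2 to compound 4 (within the scatter), where 3-chlorophenyl replaces pyridin-4-yl, separates the compounds beyond the scatter. No measurement available here explains these differences.

The compounds shown leave open how a cyclohexyl ring or a benzyl group on this nitrogen would read, and whether a methoxy group in place of chloro would stay level with compound 4. Each number also comes from a single concentration, so the potency of these compounds remains open.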